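The compounds below may be only part of what the source reports. "The series", "measured", "known", "first", "only" and "open" are said of these compounds alone.

Among the compounds with values here, compound 1 `COc1ccc(CN(C(=O)CSc2nc3ccccc3s2)c2cc(OC)c(OC)c(OC)c2)cc1C` is the only member of this small set with a real number: in a functional assay on MGC-803 cells (Homo sapiens) for antiproliferative activity, read by MTT assay, with a stated time of 48 h (a lower number here means a stronger inhibitor, a higher number a weaker inhibitor), compound 1 gives 6360 nM. Compound 2 `COc1cc(N(Cc2ccc(Cl)cc2)C(=O)CSc2nc3ccccc3s2)cc(OC)c1OC` reaches only a limit of the assay, > 80000 nM, in this assay. Compound 3 `COc1cc(N(Cc2ccc(F)cc2)C(=O)CSc2nc3ccccc3s2)cc(OC)c1OC` likewise reaches only a limit, > 80000 nM. Both are large steps away from compound 1: an at least 12-fold higher number from compound 1 to compound 2 (1.09 log units; beyond the scatter), and an at least 12-fold higher number from compound 1 to compound 3 (1.09 log units; beyond the scatter). These two steps rest on (the limit of > 80000 nM in this assay, at which 2 of the 3 values shown sit), so their true size is not known.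

Compound 4 `COc1ccc(CN(C(=O)CSc2nc3ccccc3s2)c2cc(OC)c(OC)c(OC)c2)cc1C(F)(F)F` is not yet measured. It differs from compound 1 by trifluoromethyl in place of methyl on an aromatic carbon. The two measured steps swap out the whole 4-methoxy-3-methylphenyl, whereas compound 4 keeps the methoxy group and changes only the methyl, so they bear on it only loosely; a weakening in this assay that stays short of the limit seems the likelier outcome. Compound 4 is therefore expected to give about 13000 nM, within 4000 nM to 45000 nM. The expected step is a 2.0-fold higher number from compound 1 to compound 4 (0.31 log units; beyond the scatter).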

Compound 4, half-maximal inhibitory concentration: 25200 nM
Beside the measured number, compound 4's estimate is 1.9-fold (0.29 log units) below it, within the range that was stated.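

In this assay, within the data shown here, this is the first change confined to the methyl group of the 4-methoxy-3-methylphenyl, with the methoxy group kept, and trifluoromethyl in its place weakens the compound only modestly: a 4.0-fold higher number from compound 1 to compound 4 (0.60 log units; beyond the scatter). Compound 4 still gives a real number, so this position accepts a larger group without the activity falling to the limit of the assay. It also stands clear of the compounds with a 4-chlorophenyl or 4-fluorophenyl: an at least 3.1-fold lower number from compound 2 to compound 4 (0.50 log units; beyond the scatter), and an at least 3.1-fold lower number from compound 3 to compound 4 (0.50 log units; beyond the scatter). The true size of those two steps remains unknown: the limit of > 80000 nM in this assay, at which 2 of the 4 values shown sit.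

On these data alone, with only methyl and trifluoromethyl compared at this position, it remains open how a nitrile or an amine there would behave. As far as these compounds go, it also remains open whether the methoxy group alone, with no group at this position, would keep a measurable activity.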